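Chain branching and mouse exposure: compound 2 to compound 3

The compounds below may be only part of what the source reports. "The series", "measured", "known", "first", "only" and "open" are said of these compounds alone.

Measured compounds:
compound 1 `CN(Cc1ccccc1OCCCCCC(=O)O)C(=O)c1ccc(-c2ccco2)cc1` — 1100 ng.h/mL
compound 2 `CC(CCCCOc1ccccc1CN(C)C(=O)c1ccc(-c2ccco2)cc1)C(=O)O` — 11400 ng.h/mL

In an ADME assay on the whole organism (strain CD-1) for pharmacokinetics, with Mus musculus as the target, at a dose of 3 mg/kg by the intravenous route (on this read-out higher numbers stand for higher exposure at the dose given and lower numbers for lower exposure), compound 1 gives 1100 ng.h/mL, and compound 2 gives 11400 ng.h/mL. Going by the values given here, compound 2 stands highest of the two numbers; its only neighbour is compound 1, and the single measured step, a 10-fold higher number from compound 1 to compound 2 (1.02 log units; beyond the scatter), is beyond the scatter and large. That step is the methyl in place of hydrogen on a saturated chain carbon bound to a carbonyl carbon and a saturated chain carbon.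

Compound 3 `C[C@@H](CCCOc1ccccc1CN(C)C(=O)c1ccc(-c2ccco2)cc1)CC(=O)O` is the next analogue. It differs from compound 2 by 1-(carboxymethyl)ethyl in place of 2-carboxypropyl on a saturated chain carbon, three bonds along the chain from an oxygen on an aromatic ring. Compound 3 keeps the same atoms as compound 2, but the saturated chain carbon bound to the carbonyl carbon no longer carries the methyl, which now sits further along the chain.

Among the compounds with values here, only one measured step bears on this change, and it does not match it: nothing shows how moving the methyl along the chain behaves in this assay. Because of a 10-fold higher number from compound 1 to compound 2 (1.02 log units; beyond the scatter), some of the gain over compound 1 is taken to depend on the methyl where it stands in compound 2, so a downward step, smaller than that one, is expected. The expected step is a 2.3-fold lower number from compound 2 to compound 3 (0.36 log units; beyond the scatter). Compound 3 is therefore estimated at 5000 ng.h/mL, with a range from 1500 ng.h/mL to 15000 ng.h/mL.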

Compound 3, area under the concentration-time curve: 30800 ng.h/mL
For compound 3 the middle estimate is 6.2-fold (0.79 log units) below the measured one; measured number outside the range, above it.
By their numbers in this assay, from the lowest: compound 1; then compound 2; then compound 3.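

Working note on the methyl position: with 1-(carboxymethyl)ethyl in place of 2-carboxypropyl, this assay shows a 2.7-fold higher number from compound 2 to compound 3 (0.43 log units; beyond the scatter) and no loss, so the higher numbers on this chain do not require the methyl to stand on the saturated chain carbon bound to the carbonyl carbon. Methyl in place of hydrogen on a saturated chain carbon bound to two saturated chain carbons gives a 28-fold higher number from compound 1 to compound 3 (1.45 log units; beyond the scatter) and thus the largest step seen so far, so both chain positions carrying a methyl read higher than the unbranched chain of compound 1, with the further position reading higher still. No measurement in hand accounts for either rise or for the difference between the two positions.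

The compounds shown do not tell whether the opposite configuration at the defined stereocentre of compound 3 would read the same, or how an ethyl or a gem-dimethyl at that chain carbon would behave. They also leave open whether the gain would survive a tetrazole or a primary amide in place of the carboxylic acid.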